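A few compounds are considered here, and "the series" means these few. Any claim that something is new, unique, unknown or untested is made for them only; others in the source may bear on it.

Measured in a functional assay on PC-3 cells (Homo sapiens) for inhibition, read by sulforhodamine B assay, with a stated time of 72 h; a lower number here means a stronger inhibitor, a higher number a weaker inhibitor:

- compound 1 `Nc1sc(-c2ccc(Cl)cc2)c(-c2ccc(Cl)cc2)c1C(=O)N1CCCCC1` gives 14300 nM
- compound 2 `Nc1sc(-c2ccc(Cl)cc2)c(-c2ccc(Cl)cc2)c1C(=O)NC1CCCCC1` gives 7300 nM

Only these two numbers exist so far. Compound 2 and compound 1 lie within the usual scatter of each other, so neither can be ranked above the other.

The next compound is compound 3 `Nc1sc(-c2ccc(Cl)cc2)c(-c2ccc(Cl)cc2)c1C(=O)NC1CCC1`, which keeps the shared core of compound 2 and carries cyclobutyl in place of cyclohexyl on an amide-type nitrogen.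

For the measured compounds named here, one measured step bears on this, and only indirectly. It is a 2.0-fold lower number from compound 1 to compound 2 (0.29 log units; within the scatter), the exchange of piperidin-1-yl for cyclohexylamino on the same carbonyl carbon. That step did not move the number beyond the scatter. Going by the values given here, no measured step changes the ring on this nitrogen from one size to another, so the evidence is thin and the range must stay wide.

No clear change is therefore expected in this assay, and the expected step is a 1.2-fold higher number from compound 2 to compound 3 (0.09 log units; within the scatter). For compound 3 the estimated value is 9000 nM, with an expected range from 3500 nM to 23000 nM.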

Compound 3, half-maximal inhibitory concentration: 24800 nM
For compound 3 the middle estimate is 2.8-fold (0.44 log units) below the measured one; the measured number lies above the stated range.
By their numbers in this assay, from the lowest: compounds 2, 1 and 3 (each within the scatter of the next, the first and the last beyond it).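

In this assay the carbon ring on the amide-type nitrogen now shows an effect: cyclobutyl in place of cyclohexyl gives a 3.4-fold higher number from compound 2 to compound 3 (0.53 log units; beyond the scatter) for this change, the first step among these compounds to pass the scatter, though only modestly. For the compounds shown here, the exchange of piperidin-1-yl for cyclobutylamino on the carbonyl carbon gives a 1.7-fold higher number from compound 1 to compound 3 (0.24 log units; within the scatter) and so leaves compound 3 and compound 1 unranked, which means that the effect of the smaller ring rests on the single pair of compound 2 and compound 3. No measurement is available that would account for this difference.

Going by these compounds, with only the four-membered and six-membered rings compared on this nitrogen, it remains open whether cyclopentyl or cycloheptyl would continue the same direction or whether the number depends on ring size in some less regular way. On these data alone, it is also open how an open chain such as n-butyl, or a cyclohexyl ring carrying a hydroxyl group or an amine, would behave at this nitrogen with the shared core unchanged.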